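A few compounds are considered here, and "the series" means these few. Any claim that something is new, unique, unknown or untested is made for them only; others in the source may bear on it.

In an ADME assay on BJ cells (Homo sapiens) for cytotoxicity, with a stated time of 72 h (on this read-out higher numbers stand for an effect only at larger amounts of compound and lower numbers for an effect already at smaller amounts), compound 1 (`C=C[C@@](C)(/C=C/c1ccc(O)cc1)CC/C=C/C(=O)OCc1ccccc1`) reads > 36600 nM, which is a limit. Compound 2 (`C=C[C@@](C)(/C=C/c1ccc(O)c(/C=C/C(=O)OCC)c1)CCC=C(C)C`) reads > 36600 nM, also a limit. Compound 3 (`CCOC(=O)/C=C/c1cc(/C=C/[C@](C)(/C=C/c2ccc(OC)cc2)CCC=C(C)C)ccc1O`) reads > 36600 nM, again a limit. Among the compounds with values here, the series so far shows (the limit of > 36600 nM in this assay, at which 3 of the 3 values shown sit). Within the data shown here, the one measured step, a step that the two limits leave unreadable from compound 2 to compound 3, concerns a different place and gives no size to carry over. Compound 4 (`COc1ccc(/C=C/[C@@](C)(/C=C/c2ccc(O)c(/C=C/C(C)=O)c2)CCC=C(C)C)cc1`) has methyl in place of ethoxy on a carbonyl carbon, turning 2-(ethoxycarbonyl)ethenyl into 2-acetylethenyl: methyl in place of ethoxy on a carbonyl carbon. Among the measured compounds shown here, no measured step covers this change, so the expectation rests only on compound 3, with its limit of > 36600 nM, and no direction can be assigned. The expected step is a step that the limit leaves unreadable from compound 3 to compound 4, with nothing anticipated beyond the scatter. For compound 4 the estimate is 40000 nM, with an expected range of 12000 nM to 100000 nM.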

Compound 4, half-maximal effective concentration: 12300 nM
Compound 4: the middle estimate sits 3.3-fold (0.51 log units) above what was measured; the measured number falls inside the stated range.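

In this assay, within the data shown here, methyl in place of ethoxy on a carbonyl carbon gives an at least 2.9-fold lower number from compound 3 to compound 4 (0.47 log units; beyond the scatter), so this position affects the read-out, which the earlier compounds could not show. Compound 4 is the only compound shown with a number rather than a limit: the limit of > 36600 nM in this assay, at which 3 of the 4 values shown sit. Among these compounds, the one earlier step, between two limits, cannot be read.

As far as these compounds go, compound 3 has only a limit, so the full size of the step stays open. From the compounds shown here alone, whether an amine or a longer chain in place of methyl on this carbonyl carbon would lower the number further also stays open.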